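Shortening the Second Acid Chain of a Leukotriene Antagonist

The source may hold more compounds than are shown below. What is called first, only, known or untested is meant among the compounds shown, and "the series" means these compounds.

Going by the values given here, compound 1 `Cc1c(Cl)cccc1CCCCOc1ccc(C#Cc2cccc3c(CCCC(=O)O)c(C)n(CC(=O)O)c23)cc1` gives 0.22 nM in a functional assay on CHO-K1 cells for antagonist activity at cysteinyl leukotriene receptor 1 (Homo sapiens), read by fluorescence and calcium flux, with stated times of 30 min and 1 h (a lower number here means a stronger inhibitor, a higher number a weaker inhibitor), the lowest of the three numbers measured so far. Compound 2 `Cc1c(Cl)cccc1CCCCOc1ccc(C#Cc2cccc3c(CCCC(=O)O)c(C)n(CCC(=O)O)c23)cc1` gives 17 nM and compound 3 `Cc1c(Cl)cccc1CCCCOc1ccc(C#Cc2cccc3c(CCCC(=O)O)c(C)n(CCCCC(=O)O)c23)cc1` gives 56 nM; both lengthen the acid chain on the aromatic nitrogen, and the steps were a 77-fold higher number from compound 1 to compound 2 (1.89 log units; beyond the scatter) and a 250-fold higher number from compound 1 to compound 3 (2.41 log units; beyond the scatter). Compound 4 `Cc1c(Cl)cccc1CCCCOc1ccc(C#Cc2cccc3c(CC(=O)O)c(C)n(CC(=O)O)c23)cc1` instead alters the other acid chain: carboxy in place of 2-carboxyethyl on a saturated chain carbon bound to an aromatic carbon. Among the compounds with values here, no measured step touches this chain, but the steps at the nitrogen show that shifting an acid along its chain is punished heavily, so a clear loss is expected here as well, plausibly somewhat smaller, giving a 36-fold higher number from compound 1 to compound 4 (1.56 log units; beyond the scatter). Compound 4 is therefore estimated at 8 nM, within a range from 1 nM to 80 nM.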

Compound 4, half-maximal inhibitory concentration: 0.47 nM
Estimate against measurement, compound 4: 17-fold (1.23 log units) above, and the stated range ends above it.
By their numbers in this assay, from the lowest: compound 1; then compound 4; then compound 2; then compound 3.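

Shortening the acid chain on the saturated chain carbon bound to an aromatic carbon gives a 2.1-fold higher number from compound 1 to compound 4 (0.33 log units; beyond the scatter) and so costs far less than the changes to the chain on the aromatic nitrogen. The two acid chains therefore do not answer alike, and the nitrogen chain was a poor guide to this one. The same lengthening goes in opposite directions in the two places, raising the number on the nitrogen chain and lowering it on the other: the same change on two cores in this assay, a 3.3-fold higher number (0.52 log units; beyond the scatter) from compound 2 to compound 3 and a 2.1-fold lower number (0.33 log units; beyond the scatter) from compound 4 to compound 1, 7.0-fold (0.85 log units) apart, beyond the scatter of two such steps.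

Open, from the compounds shown here alone, is how a longer chain, such as 3-carboxypropyl, would behave at this place. Also open, going by these compounds, is whether an amide or an ester could stand in for the carboxylic acid here.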